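A halogen swap on the weakest compound so far

The compounds below may be only part of what the source reports. "The series", "measured", "known", "first", "only" and "open" are said of these compounds alone.

In a functional assay on MDA-MB-231 cells (Homo sapiens) for cytotoxicity, read by MTT assay, with a stated time of 72 h (a higher number here means a weaker inhibitor, a lower number a stronger inhibitor), compound 1 (`Cc1ccc(NC(=O)CN2CCN(c3nnc(Cc4ccncc4)c4ccccc34)CC2)c(C)c1`) gives 240 nM and compound 2 (`O=C(CN1CCN(c2nnc(Cc3ccncc3)c3ccccc23)CC1)Nc1ccc(Br)cc1`) gives 19 nM. Compound 3 (`O=C(CN1CCN(c2nnc(Cc3ccccc3)c3ccccc23)CC1)Nc1ccc(Br)cc1`) gives 12400 nM, the highest number of the three, which makes it the weakest inhibitor here.

Compound 4 (`O=C(CN1CCN(c2nnc(Cc3ccccc3)c3ccccc23)CC1)Nc1ccc(F)c(Cl)c1`) is still unmeasured. It has 3-chloro-4-fluorophenyl in place of 4-bromophenyl on an amide-type nitrogen.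

Among the measured compounds shown here, only one measured step changes that same place: a 13-fold lower number from compound 1 to compound 2 (1.10 log units; beyond the scatter). This large step, with 4-bromophenyl in place of 2,4-dimethylphenyl, shows that a change there can move the number well beyond the scatter. However, it was seen with pyridin-4-yl still in the molecule, and it does not involve the incoming group, so it gives no direction for this swap. The other large step, a 650-fold higher number from compound 2 to compound 3 (2.81 log units; beyond the scatter), came from phenyl in place of pyridin-4-yl. That is a different place, and compound 4 keeps the phenyl of compound 3, so that step is not repeated.

In this assay, the estimated step is a 1.4-fold lower number from compound 3 to compound 4 (0.14 log units; within the scatter), which is expected to stay within the scatter, with no firm direction. Compound 4 is expected at about 9000 nM, with an estimated range of 2000 nM to 30000 nM.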

Compound 4, half-maximal inhibitory concentration: 7360 nM
For compound 4 the middle estimate is 1.2-fold (0.09 log units) above the measured one; measured number inside the range.
By their numbers in this assay, from the lowest: compound 2; then compound 1; then compounds 4 and 3 (each within the scatter of the next).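

With phenyl in place of pyridin-4-yl, the group on the amide-type nitrogen can change from 4-bromophenyl to 3-chloro-4-fluorophenyl with only a 1.7-fold lower number from compound 3 to compound 4 (0.23 log units; within the scatter) in this assay, so this pair cannot be told apart. Among the compounds shown here, the only earlier step at this place, a 13-fold lower number from compound 1 to compound 2 (1.10 log units; beyond the scatter), was large, so the new result shows that a change on this nitrogen does not always move the number beyond the scatter, although the two steps differ both in the groups exchanged and in the pyridin-4-yl or phenyl elsewhere in the molecule. No measurement at hand accounts for the small size of this step or for the contrast with the earlier one.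

The compounds shown leave open whether the same swap would stay as small with pyridin-4-yl in the molecule, since no compound pairs 3-chloro-4-fluorophenyl with that ring. From the compounds shown here alone, it also remains open how the number would respond if an amine or a carboxylic acid stood on the phenyl ring attached to the amide-type nitrogen, in place of bromine, chlorine or fluorine.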